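The source may hold more compounds than are shown below. What is called first, only, known or untested is meant among the compounds shown, and "the series" means these compounds.

Compound 1 `O=C(Nc1cccc(-n2cc(-c3ccncc3)c(-c3ccc(Cl)c(O)c3)n2)c1)Nc1cccc(C(F)(F)F)c1`: > 32500 nM
Compound 2 `O=C(Nc1cccc(-n2cc(-c3ccncc3)c(-c3ccc(Cl)c(O)c3)n2)c1)Nc1ccc(Cl)c(Cl)c1`: 14300 nM

In a functional assay on CAKI-1 cells (Homo sapiens) for inhibition, read by sulforhodamine B assay, with a stated time of 48 h (on this read-out higher numbers stand for weaker inhibition of growth and lower numbers for stronger inhibition of growth), compound 1 reaches only a limit, > 32500 nM, so its place among the numbers is known only as the limit of > 32500 nM in this assay, at which 1 of the 2 values shown sits. Compound 2 gives 14300 nM. Among the compounds with values here, the single measured step, an at least 2.2-fold lower number from compound 1 to compound 2 (0.35 log units; beyond the scatter), alters the same aryl ring on the amide-type nitrogen that compound 3 `O=C(Nc1cccc(-n2cc(-c3ccncc3)c(-c3ccc(Cl)c(O)c3)n2)c1)Nc1cc(C(F)(F)F)cc(C(F)(F)F)c1` alters, where (trifluoromethyl in place of hydrogen on an aromatic carbon). Within the data shown here, no measured step adds a second trifluoromethyl group, so the change is expected to bring none beyond the scatter, with a fair chance of another limit. Compound 3 is therefore estimated at 40000 nM, within 15000 nM to 100000 nM. This amounts to an expected step that the limit leaves unreadable from compound 1 to compound 3.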

Compound 3, concentration for total growth inhibition: 4420 nM
The estimate for compound 3 lay 9.0-fold (0.96 log units) above the measured number, and the stated range ends above it.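

In this assay, trifluoromethyl placed on an aromatic carbon, meta to a trifluoromethyl group already present, gives an at least 7.3-fold lower number from compound 1 to compound 3 (0.86 log units; beyond the scatter). The earlier step exchanged one substituent pattern for another, whereas this one shows that adding to the ring while keeping the first trifluoromethyl also lowers the number beyond the scatter. The value of compound 1 is only a limit, so the full size of this step stays unknown: the limit of > 32500 nM in this assay, at which 1 of the 3 values shown sits.

As far as these compounds go, whether a smaller group at this position, such as a methyl or a chlorine, would do the same remains open. So does the outcome with an amine or a carboxylic acid there.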